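The source may report more compounds than this note shows. Statements on the series, on what has been measured and on what is new or still open speak of the compounds shown alone.

Compound 1 `COc1cc(OC)c(-c2coc3cc(OCC=C(C)C)ccc3c2=O)cc1OC`: 1580 nM
Compound 2 `C#CCOc1ccc2c(=O)c(-c3cc(OC)c(OC)cc3OC)coc2c1`: 3680 nM
Compound 3 `COc1cc(OC)c(-c2coc3cc(OCC(=O)c4cccc(C(F)(F)F)c4)ccc3c2=O)cc1OC`: > 10000 nM

These values come from a functional assay on A-375 cells (Homo sapiens) for antiproliferative activity, read by MTT assay, with a stated time of 24 h; on this read-out higher numbers stand for weaker inhibition and lower numbers for stronger inhibition. Compound 3 gives only a limit of the assay, > 10000 nM, not a number.

Compound 4 `COc1cc(OC)c(-c2coc3cc(OCc4ccccc4F)ccc3c2=O)cc1OC` is not yet measured. It carries 2-fluorophenyl in place of (3-(trifluoromethyl)phenyl)carbonyl on a saturated chain carbon bound to an oxygen on an aromatic ring.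

Two measured steps lead to compound 3, an at least 6.3-fold higher number from compound 1 to compound 3 (0.80 log units; beyond the scatter) and an at least 2.7-fold higher number from compound 2 to compound 3 (0.43 log units; beyond the scatter). A third, a 2.3-fold higher number from compound 1 to compound 2 (0.37 log units; beyond the scatter), is also beyond the scatter. None of them involves 2-fluorophenyl, so they suggest only a size and direction. A modest move to lower numbers is expected, as an estimated at least 2.5-fold lower number from compound 3 to compound 4 (0.39 log units; beyond the scatter). For compound 4 the estimate is 4000 nM, with an expected range of 1300 nM to 10000 nM.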

Compound 4, half-maximal inhibitory concentration: 2100 nM
Estimate against measurement, compound 4: 1.9-fold (0.28 log units) above, within the range that was stated.
By their numbers in this assay, from the lowest: compounds 1, 4 and 2 (each within the scatter of the next, the first and the last beyond it). At a limit, above all of these: compound 3.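

Putting 2-fluorophenyl on this saturated chain carbon gives an at least 4.7-fold lower number from compound 3 to compound 4 (0.67 log units; beyond the scatter), so the loss seen with (3-(trifluoromethyl)phenyl)carbonyl does not extend to every group with an aromatic ring at this place. The value of compound 3 is a limit, not a number: the limit of > 10000 nM in this assay, at which 1 of the 4 values shown sits. The other two steps, a 1.8-fold lower number from compound 2 to compound 4 (0.24 log units; within the scatter) and a 1.3-fold higher number from compound 1 to compound 4 (0.12 log units; within the scatter), leave 2-fluorophenyl not told apart from ethynyl or from 2-methylprop-1-en-1-yl.

On these data alone, it remains open whether the carbonyl or the trifluoromethyl goes with the limit of compound 3. Also open, as far as these compounds go, is what an unsubstituted phenyl or a 3-(trifluoromethyl)phenyl without the carbonyl would give at this place.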